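Lactam removed, carboxylate moved: a trypsin step beyond the limit

The source may report more compounds than this note shows. Statements on the series, on what has been measured and on what is new or still open speak of the compounds shown alone.

Compound 1 `O=C(NC[C@H]1CN(c2ccc(N3CCC(C(=O)O)CC3)cc2)C(=O)O1)c1ccc(Cl)s1`; compound 2 `CCOC(=O)C1CCN(c2ccc(N3C[C@H](CNC(=O)c4ccc(Cl)s4)OC3=O)cc2)CC1`; compound 3 `O=C(NC[C@H]1CN(c2ccc(N3CCC(C(=O)O)CC3=O)cc2)C(=O)O1)c1ccc(Cl)s1`.

Three compounds share a core and were tested in an assay on isolated protein for inhibition of Trypsin (Homo sapiens), read by spectrophotometry, with a stated time of 15 min; a higher number here means a weaker inhibitor, a lower number a stronger inhibitor. Compound 1 returned only a limit of the assay, > 100000 nM. Compound 2 likewise returned only a limit, > 100000 nM. Compound 3 also sits at a limit, > 100000 nM. Because all three values rest at the limit of > 100000 nM in this assay, at which 3 of the 3 values shown sit, the steps between them cannot be read: a step that the two limits leave unreadable from compound 1 to compound 2, a step that the two limits leave unreadable from compound 1 to compound 3 and a step that the two limits leave unreadable from compound 2 to compound 3 all stay unreadable.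

Compound 4 `O=C(NC[C@H]1CN(c2ccc(N3CCCC(C(=O)O)C3)cc2)C(=O)O1)c1ccc(Cl)s1` has not been measured in this assay. It differs from compound 3 in one place: 3-carboxypiperidin-1-yl in place of 4-carboxy-2-oxopiperidin-1-yl on an aromatic carbon. Among the compounds with values here, no measured step bears on this change in a readable way, since every value shown is a limit. The expectation for compound 4 therefore rests only on the fact that compound 3 gives a limit, and compound 4 is expected to give a limit as well. The step from compound 3 to compound 4 is thus estimated as a step that the limit leaves unreadable from compound 3 to compound 4, with no size readable beyond the scatter. Compound 4 is estimated at 200000 nM in this assay, within a range of 50000 nM to 1000000 nM.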

Compound 4, inhibition constant: > 100000 nM
Compound 4 gave a limit, no number (the forecaster's own chance of this, stated with the estimate: 85%); the middle value lies beyond the limit too.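

In this assay compound 4 gives only a limit, > 100000 nM. Its steps from compound 1, compound 2 and compound 3 cannot be read: the limit of > 100000 nM in this assay, at which 4 of the 4 values shown sit. The compounds shown leave open whether 3-carboxypiperidin-1-yl and 4-carboxypiperidin-1-yl differ at all in this assay, and how strongly any of the four compounds inhibits.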